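The source may report more compounds than this note shows. Statements on the series, on what has been measured and on what is new or still open speak of the compounds shown alone.

Measured so far:
compound 2 `Cc1cccc(Cl)c1C(=O)NC(CCN(C)C)c1ccc(Cl)cc1` 5130 nM
compound 1 `Cc1c(Cl)cccc1C(=O)NC(CCN(C)C)c1ccc(Cl)cc1` 1740 nM
compound 3 `CN(C)CCC(OC(=O)Nc1ccc2ccccc2c1)c1ccc(Cl)cc1` 525 nM

In an assay on NIH3T3 cells with Urotensin-2 receptor (Homo sapiens) as the target (a higher number here means that more compound is needed for the effect, a lower number that less compound is needed), compound 2 stands highest of the three numbers; its nearest neighbour is compound 1 at 1740 nM, the furthest compound 3 at 525 nM. Within the data shown here, the one single-point step, a 2.9-fold higher number from compound 1 to compound 2 (0.47 log units; beyond the scatter), moves a chlorine and a methyl within an aryl amide.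

Compound 4 `CN(C)CCC(NC(=O)NCc1ccccc1)c1ccc(Cl)cc1` is reached from compound 2 by benzylamino in place of 2-chloro-6-methylphenyl on a carbonyl carbon. Among the measured compounds shown here, no measured step exchanges the aryl amide for a urea, so a 2.9-fold higher number from compound 1 to compound 2 (0.47 log units; beyond the scatter) does not bear directly on it. Compound 2 and compound 3 differ in several places at once; their two values only show that the carbamate with a naphthyl group sits lower. Expected for compound 4 is a 2.6-fold lower number from compound 2 to compound 4 (0.41 log units; beyond the scatter), with wide uncertainty. The estimate for compound 4 is 2000 nM, range 400 nM to 10000 nM.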

Compound 4, half-maximal effective concentration: 2000 nM
For compound 4 middle estimate and measured number coincide at the digits printed, within the range that was stated.
By their numbers in this assay, from the lowest: compound 3; then compounds 1 and 4 (each within the scatter of the next); then compound 2.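

In this assay the carbonyl carbon accepts benzylamino in place of an aryl group, giving a urea: a 2.6-fold lower number from compound 2 to compound 4 (0.41 log units; beyond the scatter) recovers the loss seen with 2-chloro-6-methylphenyl. Against the other aryl amide, a 1.1-fold higher number from compound 1 to compound 4 (0.06 log units; within the scatter) shows that benzylamino and 3-chloro-2-methylphenyl cannot be told apart here. The aryl substitution pattern therefore matters more than the presence of an aryl group on the carbonyl carbon, at least across these three compounds. No measurement at hand accounts for these shifts.

On these data alone, whether the urea nitrogen or the methylene of benzylamino carries the result stays open. Also open, as far as these compounds go, is how anilino or the longer phenethylamino would read on the same carbonyl carbon.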